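Chloro added to the fused ring of compound 3

This account rests on a few compounds, and the source may have more. Where it says the series, first, only, none or still open, it means among the compounds named here.

Compound 3 `COc1ccc(C2=NN(C3=NC(=O)/C(=C4\C(=O)Nc5ccccc54)S3)C(c3ccc(OC)cc3)C2)cc1` gives in a functional assay on cells (Cancer cell lines, Homo sapiens) for cytotoxicity, read by sulforhodamine B assay, with a stated time of 48 h (a lower number here means a stronger inhibitor of growth, a higher number a weaker inhibitor of growth), a value of 100000 nM, the highest of the three measured numbers. Compound 2 `COc1ccc(C2CC(c3ccccc3)=NN2C2=NC(=O)/C(=C3\C(=O)Nc4ccccc43)S2)cc1` gives 3350 nM, and compound 1 `O=C1N=C(N2N=C(c3ccccc3)CC2c2ccccc2O)S/C1=C1/C(=O)Nc2ccc(Br)cc21` gives 930 nM. For the measured compounds named here, the only measured single change, a 30-fold higher number from compound 2 to compound 3 (1.47 log units; beyond the scatter), concerns a different place and does not bear directly on the change considered here. Compound 4 `COc1ccc(C2=NN(C3=NC(=O)/C(=C4\C(=O)Nc5ccc(Cl)cc54)S3)C(c3ccc(OC)cc3)C2)cc1` differs from compound 3 by chloro in place of hydrogen on an aromatic carbon. Going by the values given here, no measured step covers this position; compound 1, which carries a bromo and differs in more than one place, shows the lowest number at 930 nM, so a moderate downward step is expected, a 3.3-fold lower number from compound 3 to compound 4 (0.52 log units; beyond the scatter), with little confidence. Compound 4 is therefore estimated at 30000 nM, in a range from 5000 nM to 100000 nM.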

Compound 4, concentration for total growth inhibition: 710 nM
For compound 4 the middle estimate is 42-fold (1.63 log units) above the measured one; the whole stated range lies above it.
By their numbers in this assay, from the lowest: compounds 4 and 1 (each within the scatter of the next); then compound 2; then compound 3.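

In this assay, chloro in place of hydrogen on the six-membered aromatic ring of the fused system gives a 140-fold lower number from compound 3 to compound 4 (2.15 log units; beyond the scatter). For the compounds shown here, this is the first single change read at this position, and it shows that one added heavy atom here is enough for a large step. Nothing available accounts for the size of this step. On these data alone, it stays open whether an amine or a carboxylic acid on this carbon would give a step of similar size. As far as these compounds go, it also stays open whether chloro would give such a step on compound 2.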